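Chloro on a Fused Aromatic Ring: A Predicted Stability Step

The source may hold more compounds than are shown below. What is called first, only, known or untested is meant among the compounds shown, and "the series" means these compounds.

Three compounds sharing a sulfonyl-linked core have been run in an ADME assay on S9 fraction from liver (Mus musculus, strain ICR/CD-1) for metabolic stability, read by LC-MS, using NADPH, with a stated time of 5 min, tested at 2 uM; a lower number here means that the compound disappears faster, a higher number that the compound lasts longer. Compound 1 `COc1ccc(-c2cccc(S(=O)(=O)N3CCC(N4CCC(C)CC4)CC3)c2)cc1` gives 2.4 h and compound 3 `COc1cc(C)c(S(=O)(=O)N2CCC(N3CCC(C)CC3)CC2)cc1C(C)C` gives 0.133 h. Compound 2 `CC1CCN(C2CCN(S(=O)(=O)c3cccc4ccccc34)CC2)CC1` gives only a limit, < 0.0834 h, so its true half-life is not known as a number. Among the measured compounds shown here, on the values shown, compound 2 therefore sits at the bottom, at the limit of < 0.0834 h in this assay, at which 1 of the 3 values shown sits, and no step between two measured compounds is available to anchor how a single change moves the read-out.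

Compound 4 `CC1CCN(C2CCN(S(=O)(=O)c3ccc(Cl)c4ccccc34)CC2)CC1` is the unmeasured partner of compound 2. The change is chloro in place of hydrogen on an aromatic carbon; chloro replaces hydrogen on an aromatic carbon of a six-membered aromatic ring of carbon only, part of a fused system of two rings. For the measured compounds named here, nothing among the measured compounds shows what such a chloro does in this assay.

Because compound 2 stands at the limit of < 0.0834 h in this assay, at which 1 of the 3 values shown sits, the estimated step of an at least 1.0-fold higher number from compound 2 to compound 4 (0.03 log units; that floor lies within the scatter) is expected to be small, likely within the usual scatter, with a slight lean toward a longer half-life simply because the starting point can only be read as a limit. For compound 4 the expected half-life is 0.09 h, with a range from 0.04 h to 0.25 h.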

Compound 4, half-life: 0.233 h
Compound 4: middle estimate off by 2.6-fold (0.41 log units), on the low side, and the stated range covers the measured number.
By their numbers in this assay, from the lowest: compounds 3 and 4 (each within the scatter of the next); then compound 1. At a limit, below all of these: compound 2.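

Chloro in place of hydrogen on this aromatic carbon, part of a fused system of two rings and para to a large group, gives the one single-place step in the series so far: in this assay the change brings an at least 2.7-fold higher number from compound 2 to compound 4 (0.44 log units; beyond the scatter). This shows that a change of just one heavy atom at this position goes with a longer half-life, by a step that lies beyond the scatter, which the three earlier compounds could not show since no two of them differed in one place. The true step may be larger than the printed one, because the starting point is only a limit and not a number: the limit of < 0.0834 h in this assay, at which 1 of the 4 values shown sits.

The compounds shown hold this one change at this one position, so it stays open whether chloro on another carbon of the same ring, or on the cores of compound 1 or compound 3, would go the same way. It also stays open whether fluoro, a nitrile or an amine on this same carbon would lengthen the half-life as chloro does, and the reason for the step is not shown by these data.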